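The source may report more compounds than this note shows. Statements on the series, on what has been measured and on what is new or still open speak of the compounds shown alone.

Working notes on the series. Compound 1 `COc1cc(-c2cc(/C=C/C(=O)c3ccc(N)cc3)[nH]n2)cc(OC)c1OC` in a functional assay on CCRF-CEM cells (Homo sapiens) for inhibition, read by sulforhodamine B assay, with a stated time of 48 h (on this read-out higher numbers stand for weaker inhibition of growth and lower numbers for stronger inhibition of growth), gives 550 nM. Compound 2 `COc1ccc(-c2cc(/C=C/C(=O)c3ccc(OC)c(OC)c3)[nH]n2)cc1` in this assay gives 1340 nM. Compound 3 `COc1ccc(-c2cc(/C=C/C(=O)c3ccc(N)cc3)[nH]n2)cc1OC` in this assay gives 1740 nM, the highest of the three numbers; its gap to compound 2 lies within the scatter, while its gap to compound 1 lies beyond it. For the measured compounds named here, the only single-point step among the measured compounds is a 3.2-fold higher number from compound 1 to compound 3 (0.50 log units; beyond the scatter), a methoxy leaving an aromatic carbon and weakening growth inhibition by a modest amount.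

Compound 4 `COc1ccc(-c2cc(/C=C/C(=O)c3ccc(N)cc3)[nH]n2)cc1` is not yet measured. It differs from compound 3 by hydrogen in place of methoxy on an aromatic carbon. This repeats the kind of change seen in the step from compound 1 to compound 3, now on the six-membered aromatic ring of carbon only that already carries just two methoxy groups, leaving a single methoxy. That step is the only one bearing on the question, so a further rise of similar or somewhat smaller size is expected, with the caution that a single precedent leaves room for the step to fall within the scatter. Compound 4 is therefore expected at 3500 nM, with a range of 1500 nM to 8000 nM. The estimated step is a 2.0-fold higher number from compound 3 to compound 4 (0.30 log units; within the scatter).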

Compound 4, concentration for 50% growth inhibition: 1320 nM
Compound 4: the middle estimate sits 2.7-fold (0.42 log units) above what was measured; the whole stated range lies above it.
By their numbers in this assay, from the lowest: compound 1; then compounds 4, 2 and 3 (each within the scatter of the next).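

The same change, hydrogen in place of methoxy on an aromatic carbon, now gives a 1.3-fold lower number from compound 3 to compound 4 (0.12 log units; within the scatter) in this assay, so the methoxy ortho to a methoxy group and meta to a large group in compound 3 can leave without a change that stands clear of the scatter. Set against a 3.2-fold higher number from compound 1 to compound 3 (0.50 log units; beyond the scatter), this shows that the replacement does not carry one fixed size across the series: it reads beyond the scatter on the ring of compound 1 and within it on the ring of compound 3, so the outcome depends on which methoxy groups remain on that ring. Nothing available explains why the two steps read differently.

Still open, on these data alone, is whether the last methoxy of compound 4 can also give way to hydrogen without a step beyond the scatter. Equally open, as far as these compounds go, is how a hydroxy group, a fluorine atom or an ethoxy group would read at the position vacated in compound 4, where only methoxy and hydrogen have so far been compared.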